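Swapping an Ethyl Chain for a Fluorinated Benzyl Ring

The compounds below may be only part of what the source reports. "The series", "measured", "known", "first", "only" and "open" are said of these compounds alone.

Going by the values given here, in a functional assay on BGC-823 cells (Homo sapiens) for inhibition, read by MTT assay, with a stated time of 72 h (a lower number here means a stronger inhibitor, a higher number a weaker inhibitor), compound 1 `CCCSc1nc2nc(C)cc(N3CC[C@@H](C)[C@@H](N(C)c4ncnc5[nH]ccc45)C3)n2n1` gives 51200 nM, the highest of the three numbers measured so far. Compound 2 `Cc1cc(N2CC[C@@H](C)[C@@H](N(C)c3ncnc4[nH]ccc34)C2)n2nc(SCc3ccc(C(F)(F)F)cc3)nc2n1` gives 23300 nM and compound 3 `Cc1cc(N2CC[C@@H](C)[C@@H](N(C)c3ncnc4[nH]ccc34)C2)n2nc(SCc3ccc(Cl)cc3)nc2n1` gives 26300 nM; a 1.1-fold higher number from compound 2 to compound 3 (0.05 log units; within the scatter). Compound 4 `Cc1cc(N2CC[C@@H](C)[C@@H](N(C)c3ncnc4[nH]ccc34)C2)n2nc(SCc3ccc(F)cc3)nc2n1` has not yet been measured. It differs from compound 1 in one place: 4-fluorophenyl in place of ethyl on a saturated chain carbon bound to a sulfur. Among the compounds with values here, two measured steps bear directly on this change, each putting a substituted phenyl ring where the ethyl stood: a 2.2-fold lower number from compound 1 to compound 2 (0.34 log units; beyond the scatter), while a 1.9-fold lower number from compound 1 to compound 3 (0.29 log units; within the scatter). A step of about that size, downward, is therefore expected for compound 4: the estimate is a 1.9-fold lower number from compound 1 to compound 4 (0.28 log units; within the scatter). Compound 4 is thus expected to give 27000 nM, within a range from 12000 nM to 60000 nM.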

Compound 4, half-maximal inhibitory concentration: 44300 nM
For compound 4 the middle estimate is 1.6-fold (0.22 log units) below the measured one, and the stated range covers the measured number.
By their numbers in this assay, from the lowest: compounds 2, 3, 4 and 1 (each within the scatter of the next, the first and the last beyond it).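

With a 1.2-fold lower number from compound 1 to compound 4 (0.06 log units; within the scatter) the change to 4-fluorophenyl stays within the scatter, so a phenyl ring in place of ethyl on this carbon is not enough on its own to move the number beyond it. Fluoro in place of chloro gives a 1.7-fold higher number from compound 3 to compound 4 (0.23 log units; within the scatter) and fluoro in place of trifluoromethyl gives a 1.9-fold higher number from compound 2 to compound 4 (0.28 log units; within the scatter) and both also stay within the scatter, leaving the step from compound 1 to compound 2 as the only one shown beyond it. As far as these compounds go, what a longer chain, or a ring carrying an amine or a carboxylic acid, would do here stays open. No measurement shown explains these small differences.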